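The compounds below may be only part of what the source reports. "The series", "measured", "known", "first", "only" and "open" are said of these compounds alone.

Measured so far in a functional assay on ACHN cells (Homo sapiens) for cytotoxicity, read by MTT assay, with a stated time of 48 h; on this read-out higher numbers stand for weaker inhibition and lower numbers for stronger inhibition:

compound 1 `COc1ccc(-c2cc(C(=O)Nc3nc4ccc(F)cc4s3)nc3cc(-c4ccccc4)nn23)cc1`: 39300 nM
compound 2 `COc1ccc(-c2cc(C(=O)Nc3nc4ccc(F)cc4s3)nc3cc(-c4ccccc4)nn23)cc1OC`: 8120 nM
compound 3 `COc1ccc(-c2cc(C(=O)Nc3nc4cc(C)c(C)cc4s3)nc3cc(-c4ccccc4)nn23)cc1OC`: 8700 nM

Compound 4 `COc1cc(-c2cc(C(=O)Nc3nc4cc(C)c(C)cc4s3)nc3cc(-c4ccccc4)nn23)cc(OC)c1OC` is not yet measured in this assay. It differs from compound 3 in one place: methoxy in place of hydrogen on an aromatic carbon. The same kind of change separates compound 1 from compound 2, (methoxy in place of hydrogen on an aromatic carbon), where it gave a 4.8-fold lower number from compound 1 to compound 2 (0.68 log units; beyond the scatter). The two places are not identical: in compound 4 the entering methoxy is also meta to a methoxy group, which is not so in compound 2. The difference between the cores of compound 1 and compound 3 is not broken down here. Within the series, a 1.1-fold higher number from compound 2 to compound 3 (0.03 log units; within the scatter), so the core change left the number essentially where it was.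

The expectation for compound 3 to compound 4 is a 1.9-fold lower number from compound 3 to compound 4 (0.29 log units; within the scatter), a smaller step than the earlier one because a 4.8-fold lower number from compound 1 to compound 2 (0.68 log units; beyond the scatter) rests on a place that lacked the second flanking methoxy, and a second addition of the same kind need not repeat the first. Compound 4 is therefore estimated at 4500 nM, with a likely range from 1500 nM to 12000 nM.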

Compound 4, half-maximal inhibitory concentration: 3800 nM
Compound 4: the middle estimate sits 1.2-fold (0.07 log units) above what was measured; measured number inside the range.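

In this assay the entering methoxy again goes with a lower number, a 2.3-fold lower number from compound 3 to compound 4 (0.36 log units; beyond the scatter), so the change carries to the second core in the same direction. Set beside the earlier step, the two sizes cannot be told apart: the same change on two cores in this assay, a 4.8-fold lower number (0.68 log units; beyond the scatter) from compound 1 to compound 2 and a 2.3-fold lower number (0.36 log units; beyond the scatter) from compound 3 to compound 4, 2.1-fold (0.33 log units) apart, within the scatter of two such steps. This rests on one pair per core, and the pairs differ both in the group on the amide-type nitrogen and in the place the methoxy enters, so it does not show a fixed step size across the series or predict the step on any other core.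

Open, as far as these compounds go, is whether an ethoxy, a hydroxyl or an amine in the same place would give a step of similar size, or whether the lower number is tied to methoxy. Also open, from the compounds shown here alone, is how 3,4,5-trimethoxyphenyl behaves with 6-fluoro-1,3-benzothiazol-2-yl on the amide-type nitrogen, which would give a further pair for judging the carry-over.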